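The source may report more compounds than this note shows. Statements on the series, on what has been measured and on what is new or still open speak of the compounds shown alone.

Compound 2 `C#CCNC1CCc2c(SCCc3ccc(Br)cc3)cccc21` gives 85300 nM in an assay on isolated protein for inhibition of Amine oxidase [flavin-containing] B (Homo sapiens) (on this read-out lower numbers stand for stronger inhibition and higher numbers for weaker inhibition), the top of the two numbers shown, with compound 1 close by. Within the data shown here, compound 1 `C#CCNC1CCc2c(SCCc3cccc(Cl)c3)cccc21` gives 82400 nM, and the step of a 1.0-fold higher number from compound 1 to compound 2 (0.02 log units; within the scatter) is the only measured step that bears on the change to compound 3 `C#CCNC1CCc2c(SCCc3ccc(OC)cc3)cccc21`. That change is methoxy in place of bromo on an aromatic carbon, again an exchange of the group on the aromatic carbon. Among the measured compounds shown here, with one within-scatter step as the sole guide, no step beyond the scatter is expected in this assay. Compound 3 is therefore estimated at 85000 nM, with a range of 40000 nM to 180000 nM. The step this estimate means, a 1.0-fold lower number from compound 2 to compound 3 (0.00 log units; within the scatter), is expected to stay within the scatter.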

Compound 3, half-maximal inhibitory concentration: 62000 nM
Compound 3: middle estimate off by 1.4-fold (0.14 log units), on the high side, within the range that was stated.
By their numbers in this assay, from the lowest: compounds 3, 1 and 2 (each within the scatter of the next).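

In this assay methoxy in place of bromo gives a 1.4-fold lower number from compound 2 to compound 3 (0.14 log units; within the scatter) and so this position, on an aromatic carbon para to a large group, now has a non-halogen group that also stays within the scatter. The change from the 3-chlorophenyl group to the 4-methoxyphenyl group gives a 1.3-fold lower number from compound 1 to compound 3 (0.12 log units; within the scatter) and so no change among these three compounds goes beyond the scatter. No evidence at hand accounts for this. From the compounds shown here alone, whether an amine or a carboxylic acid on this aromatic carbon would move the number remains open. Going by these compounds, a longer chain at the sulfur is equally open.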